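The source may report more compounds than this note shows. Statements on the series, on what has been measured and on what is new or still open speak of the compounds shown alone.

In a functional assay on CHO cells for agonist activity at Free fatty acid receptor 1 (Homo sapiens), read by FLIPR and calcium flux (on this read-out higher numbers stand for an effect only at larger amounts of compound and lower numbers for an effect already at smaller amounts), compound 2 `O=C(O)CS(=O)(=O)c1ccc(OCc2cccc(-c3ccccc3C(F)(F)F)c2)cc1` gives 52.5 nM, the lowest of the two numbers recorded so far; compound 1 `O=C(O)CS(=O)(=O)c1ccc(OCc2cccc(-c3ccccc3F)c2)cc1` gives 257 nM. Among the compounds with values here, the one step between them, a 4.9-fold lower number from compound 1 to compound 2 (0.69 log units; beyond the scatter), is the only measured change at this position. Compound 3 `CC(C)c1ccccc1-c1cccc(COc2ccc(S(=O)(=O)CC(=O)O)cc2)c1` differs from compound 2 by isopropyl in place of trifluoromethyl on an aromatic carbon. Within the data shown here, that earlier step bears on the new one only in part: it shows that a larger group on this aromatic carbon, in place of fluoro, went with a lower number, but no measured compound tells how isopropyl compares with trifluoromethyl there. Compound 3 is therefore expected to stay close to compound 2, with a step of a 1.2-fold higher number from compound 2 to compound 3 (0.09 log units; within the scatter) that is not expected to exceed the scatter. For compound 3 the estimated value in this assay is 65 nM, within a range from 20 nM to 200 nM.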

Compound 3, half-maximal effective concentration in the Free fatty acid receptor 1 assay: 74.1 nM
The estimate for compound 3 lay 1.1-fold (0.06 log units) below the measured number, within the range that was stated.
By their numbers in the Free fatty acid receptor 1 assay, from the lowest: compounds 2 and 3 (each within the scatter of the next); then compound 1.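

In the Free fatty acid receptor 1 assay the exchange of trifluoromethyl for isopropyl gives a 1.4-fold higher number from compound 2 to compound 3 (0.15 log units; within the scatter) and so does not separate the two groups at this aromatic carbon, although the group that enters holds 3 carbon and the group that leaves holds 1 carbon and 3 fluorine. Isopropyl in place of fluoro gives a 3.5-fold lower number from compound 1 to compound 3 (0.54 log units; beyond the scatter) on the same read-out, so a second group now follows the direction of the earlier step from fluoro. In a physicochemical assay for lipophilicity, using the shake flask method, in phosphate buffer, measured as octanol-water partition, with a stated time of 24 h, at pH 7.4, tested at 100 uM (on this read-out higher numbers stand for higher lipophilicity and lower numbers for lower lipophilicity), compound 2 gives 2.95 and compound 3 gives 3.18; the same exchange gives a number 0.23 log units higher from compound 2 to compound 3 (within the scatter) and does not separate the two compounds on this read-out either. Nothing on hand accounts for this result.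

Going by these compounds, whether a methoxy group, an amine or a tert-butyl group on this carbon would stand with compound 2 and compound 3 or with compound 1 remains open. Also open, on these data alone, is how such groups would read in the physicochemical assay.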